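A few compounds are considered here, and "the series" means these few. Any claim that something is new, unique, unknown or untested is made for them only; others in the source may bear on it.

Three compounds sharing one core differ only in the aromatic group attached to it. In a functional assay on KBVIN cells (Homo sapiens) for antiproliferative activity, read by sulforhodamine B assay, with a stated time of 3 days (a lower number here means that less compound is needed, a higher number that more compound is needed for the effect), compound 1 `CCOc1ccc(-c2cc(=O)c3c(o2)C(CC)(CC)C(=O)C(CC)=C3O)cc1` gives 7.54 uM, compound 2 `CCC1=C(O)c2c(oc(-c3cccc(OC)c3)cc2=O)C(CC)(CC)C1=O` gives 1.22 uM, and compound 3 `CCC1=C(O)c2c(oc(-c3ccccc3F)cc2=O)C(CC)(CC)C1=O` gives 3.93 uM. Compound 3 thus sits second highest of the three: the step of a 1.9-fold lower number from compound 1 to compound 3 (0.28 log units; within the scatter) lies within the scatter, while the step of a 3.2-fold higher number from compound 2 to compound 3 (0.51 log units; beyond the scatter) lies beyond it. Compound 4 `CCC1=C(O)c2c(oc(-c3cccc(C)c3C)cc2=O)C(CC)(CC)C1=O` carries 2,3-dimethylphenyl in place of 2-fluorophenyl on an aromatic carbon. Those two steps show that exchanging this aromatic group shifts the number only modestly, and a similar modest drop is expected here, a 1.6-fold lower number from compound 3 to compound 4 (0.20 log units; within the scatter). Compound 4 is therefore estimated at 2.5 uM, with a range from 1 uM to 7 uM.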

Compound 4, concentration for half-maximal effect: 0.85 uM
Compound 4: the middle estimate sits 2.9-fold (0.47 log units) above what was measured; the measured number lies below the stated range.
By their numbers in this assay, from the lowest: compounds 4 and 2 (each within the scatter of the next); then compounds 3 and 1 (each within the scatter of the next).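

At this position on the shared core, replacing 2-fluorophenyl with 2,3-dimethylphenyl changes the result clearly (a 4.6-fold lower number from compound 3 to compound 4 (0.66 log units; beyond the scatter)), although both groups hold one six-membered aromatic ring of carbon only and no hydrogen-bond donors or acceptors. Compound 4 also stands level with compound 2 (a 1.4-fold lower number from compound 2 to compound 4 (0.16 log units; within the scatter)), so two differently substituted phenyl groups now share the low end of the series, well apart from the 4-ethoxyphenyl of compound 1 (an 8.9-fold lower number from compound 1 to compound 4 (0.95 log units; beyond the scatter)). Nothing available here accounts for these differences. Still open, on these data alone, is whether either methyl alone would give the same number, and whether a phenyl group carrying an amine or a carboxylic acid would stay at this level.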